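Swapping a pyridinyl for a fluorophenyl on a piperazine

The source may report more compounds than this note shows. Statements on the series, on what has been measured and on what is new or still open speak of the compounds shown alone.

Compound 1, with the structure `Nc1ccccc1NC(=O)c1ccc(CSC(=S)N2CCN(c3cccnc3)CC2)cc1`, was tested in a functional assay on A-375 cells (Homo sapiens) for antiproliferative activity, read by CCK-8 assay, with a stated time of 72 h, tested at 8 uM; on this read-out higher numbers stand for a stronger effect at the one concentration tested and lower numbers for a weaker effect. In this assay compound 1 gives 88.8%. A close relative, compound 2 with the structure `CC1CCN(C(=S)SCc2ccc(C(=O)Nc3ccccc3N)cc2)CC1`, was tested alongside it, and in this assay compound 2 gives 87.4%. Of the two numbers measured, compound 1 has the higher one, but the gap to compound 2 is small enough to fall within the ordinary scatter of repeated runs, so the two results should be read as alike rather than ranked.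

The next compound, compound 3 with the structure `Nc1ccccc1NC(=O)c1ccc(CSC(=S)N2CCN(c3ccccc3F)CC2)cc1`, has not yet been measured in this assay. It differs from compound 1 in one place only: 2-fluorophenyl in place of pyridin-3-yl on an amine nitrogen in a ring. Among the compounds with values here, no measured pair in this small set shows the effect of such a change, so there is nothing to anchor a prediction beyond the two near-identical numbers already seen.

On that basis the step from compound 1 to compound 3 is expected to be small, a number 3.8 percentage points lower from compound 1 to compound 3 (within the scatter), not clearly beyond the scatter in either direction. Compound 3 is therefore estimated to give 85% in this assay, within a range from 70% to 95%.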

Compound 3, a percentage reported as inhibition, at one concentration (the size of the read-out at that concentration, not a potency): 79.5%
Compound 3: the middle estimate sits 5.5 percentage points above what was measured; measured number inside the range.
By their numbers in this assay, from the lowest: compounds 3, 2 and 1 (each within the scatter of the next).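

Within the data shown here, the step between these two compounds is the first in the set that isolates a single change, and in this assay it reads a number 9.3 percentage points lower from compound 1 to compound 3 (within the scatter), which means that compound 3 and compound 1 should be read as alike. On an amine nitrogen in a ring, then, the aromatic ring can lose its hetero atom and hydrogen-bond acceptor and gain a fluorine without a difference that stands clear of ordinary scatter. No supporting data bear on why this swap leaves the result within the scatter.

This one step combines two edits, so a plain phenyl group would be needed to separate the loss of the ring nitrogen from the gain of fluorine, while a non-aromatic group on the same nitrogen, such as an acetyl or a carboxylic acid on a short chain, would test whether an aromatic ring is needed there at all. Because the read-out gives the size of the effect at one concentration, it also leaves open whether compound 1 and compound 3 would differ in potency.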